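The compounds below may be only part of what the source reports. "The series", "measured", "known", "first", "only" and "open" are said of these compounds alone.

Working notes on the series. Compound 1 `COC(=O)c1cc(=O)c2cc(N)ccc2[nH]1` carries the shared core without the anilide; compound 2 `COc1cc(OC)c2c(=O)cc(C(=O)Nc3cccc(N4CCCC4)c3)[nH]c2c1` and compound 3 `COc1cc(OC)c2c(=O)cc(C(=O)Nc3cccc(-c4nccs4)c3)[nH]c2c1` carry the anilide with pyrrolidin-1-yl or 1,3-thiazol-2-yl on an aromatic carbon. In a functional assay on HepG2 cells (Homo sapiens) for antiproliferative activity, with a stated time of 72 h (a higher number here means that more compound is needed for the effect, a lower number that less compound is needed), compound 1 gives > 33700 nM, which is a limit of the assay. In this assay compound 2 gives > 58600 nM, again a limit. In this assay compound 3 gives > 54000 nM, also a limit. The step that the two limits leave unreadable from compound 2 to compound 3 cannot be read. Compound 3 thus stands at a limit, as do the two other values shown (the limit of > 33700 nM in this assay, at which 1 of the 3 values shown sits, (the limit of > 54000 nM in this assay, at which 1 of the 3 values shown sits), (the limit of > 58600 nM in this assay, at which 1 of the 3 values shown sits)). Compound 4 `COc1cc(OC)c2c(=O)cc(C(=O)Nc3cccc(-n4ccnc4)c3)[nH]c2c1` differs from compound 3 by 1H-imidazol-1-yl in place of 1,3-thiazol-2-yl on an aromatic carbon. Among the compounds with values here, no measured step gives a direction for this change; the only related step, between compound 2 and compound 3, is itself unreadable. For compound 4 the expected step in this assay is a step that the limit leaves unreadable from compound 3 to compound 4, with no direction claimed. Compound 4 is estimated at 60000 nM, range 15000 nM to 250000 nM, most likely reported as a limit.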

Compound 4, half-maximal effective concentration: > 16300 nM
Compound 4: a limit, no number (the forecaster's own chance of this, stated with the estimate: 85%); the middle value does not contradict the limit.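

In this assay compound 4 gives > 16300 nM, a limit, so the steps linking compound 2, compound 3 and compound 4 cannot be read. The compounds shown leave open how the pyrrolidin-1-yl, 1,3-thiazol-2-yl and 1H-imidazol-1-yl groups compare in antiproliferative activity.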